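Chloro at the shared position: from a measured step to an expected one

A few compounds are considered here, and "the series" means these few. Any claim that something is new, unique, unknown or untested is made for them only; others in the source may bear on it.

Compound 1 `CCCCCCCC(CCO)n1cnc2c(Cl)ncnc21` and compound 2 `CCCCCCCC(CCO)n1cnc2c(Cl)nc(Cl)nc21` differ in one place: chloro in place of hydrogen on an aromatic carbon. In a functional assay on HCT-116 cells (Homo sapiens) for antiproliferative activity, read by MTT assay, with a stated time of 48 h (a lower number here means a stronger inhibitor, a higher number a weaker inhibitor), compound 1 gives 4160 nM, and compound 2 gives 12800 nM; the step is a 3.1-fold higher number from compound 1 to compound 2 (0.49 log units; beyond the scatter).

Compound 3 `CCCCCCCCCCC(CCO)n1cnc2c(N)ncnc21` carries a different core; the difference between the two cores is not broken down here. In this assay compound 3 gives 2590 nM, a number within the scatter of that of compound 1.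

Compound 4 `CCCCCCCCCCC(CCO)n1cnc2c(N)nc(Cl)nc21` is the unmeasured partner of compound 3, and the change that leads to it is chloro in place of hydrogen on an aromatic carbon. It is the same kind of change as that from compound 1 to compound 2, though the surroundings differ: the place in compound 4 is meta to an amino group, whereas in compound 2 it is meta to a chloro group.

Resting on compound 1 and compound 2 and their step of a 3.1-fold higher number from compound 1 to compound 2 (0.49 log units; beyond the scatter), the step expected for compound 4 is a 2.5-fold higher number from compound 3 to compound 4 (0.40 log units; beyond the scatter). For compound 4 the expected value in this assay is therefore 6500 nM, between 2500 nM and 16000 nM.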

Compound 4, half-maximal inhibitory concentration: 11800 nM
Estimate against measurement, compound 4: 1.8-fold (0.26 log units) below; measured number inside the range.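

In this assay, chloro in place of hydrogen on an aromatic carbon between two ring nitrogen atoms gives a 4.6-fold higher number from compound 3 to compound 4 (0.66 log units; beyond the scatter), so on this core too the change goes with a weaker inhibitor. The step matches the earlier one in direction, and the two cannot be told apart in size: the same change on two cores in this assay, a 3.1-fold higher number (0.49 log units; beyond the scatter) from compound 1 to compound 2 and a 4.6-fold higher number (0.66 log units; beyond the scatter) from compound 3 to compound 4, 1.5-fold (0.17 log units) apart, within the scatter of two such steps This shows the change carrying across these two cores in this one cell assay, but two pairs set no rule for the series, and they show neither why the number rises nor whether the step would hold on a third core.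

Hydrogen and chloro are the only groups shown at this carbon, so it remains open how a fluoro, a bromo, a methyl or an amine there would read. From the compounds shown here alone, each core also appears with only one chain, and whether a shorter or longer chain would alter the step remains open.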